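This account rests on a few compounds, and the source may have more. Where it says the series, first, only, none or still open, it means among the compounds named here.

Measured in a functional assay on MCF7 cells (Homo sapiens) for cytotoxicity, read by sulforhodamine B assay; on this read-out lower numbers stand for stronger inhibition of growth and higher numbers for weaker inhibition of growth:
- compound 1 `CC1=CC[C@@H]([C@@](C)(O)CCCC(C)(C)NC(=S)N/N=C\c2ccccc2)CC1`: 28700 nM
- compound 2 `CC1=CC[C@@H]([C@@](C)(O)CCCC(C)(C)NC(=S)N/N=C\c2cccc(Cl)c2)CC1`: 19500 nM

Among the compounds with values here, of the two compounds measured so far, compound 2 gives 19500 nM and sits within the scatter of compound 1, so neither stands apart. Compound 3 `CC1=CC[C@@H]([C@@](C)(O)CCCC(C)(C)NC(=S)N/N=C\c2ccc(Cl)cc2)CC1` has not yet been measured. It differs from compound 2 as follows: 4-chlorophenyl in place of 3-chlorophenyl on a carbon with a double bond to nitrogen. The chlorine stays on the ring, and the shared core is untouched. Within the data shown here, the only measured step that bears on this is a 1.5-fold lower number from compound 1 to compound 2 (0.17 log units; within the scatter), with chloro in place of hydrogen on an aromatic carbon, and it stays within the scatter. No measured step moves a chloro from one ring position to another, so the data offer no reason to expect a change beyond the scatter in this assay. The expected step is a 1.0-fold higher number from compound 2 to compound 3 (0.01 log units; within the scatter). For compound 3 the estimated value is 20000 nM, with an expected range from 10000 nM to 38000 nM.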

Compound 3, concentration for total growth inhibition: 15800 nM
Compound 3: the middle estimate sits 1.3-fold (0.10 log units) above what was measured, within the range that was stated.
By their numbers in this assay, from the lowest: compounds 3, 2 and 1 (each within the scatter of the next).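

In this assay, replacing 3-chlorophenyl with 4-chlorophenyl on the carbon with a double bond to nitrogen gives a 1.2-fold lower number from compound 2 to compound 3 (0.09 log units; within the scatter), the first sign that moving the chlorine around the ring does not carry the number beyond the scatter. The comparison with the compound lacking chlorine, a 1.8-fold lower number from compound 1 to compound 3 (0.26 log units; within the scatter), also stays within the scatter, so neither chlorophenyl compound stands apart from compound 1. Nothing available explains these small differences.

It remains open whether an amine or a methoxy group on the aromatic ring would shift the number beyond the scatter, since the three compounds shown carry only hydrogen or chlorine there. Also open, on these data alone, is whether a change away from this ring, such as a longer chain in the shared core, would separate a compound from these three.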